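The source may hold more compounds than are shown below. What is called first, only, known or untested is meant among the compounds shown, and "the series" means these compounds.

Three compounds share one core and differ only in the group attached to an aromatic carbon. Compound 1 `CCCCCCCCOc1nc(N)nc2c1ncn2/C=C1/CC1(CO)CO` carries octyloxy there, compound 2 `Nc1nc(NC2CCCCC2)c2ncn(/C=C3/CC3(CO)CO)c2n1` carries cyclohexylamino, and compound 3 `CCCNc1nc(N)nc2c1ncn2/C=C1/CC1(CO)CO` carries propylamino. In an ADME assay on BCBL1 cells (Homo sapiens) for cytotoxicity, with a stated time of 7 days (a lower number here means that less compound is tolerated, a higher number that more compound is tolerated), compound 1 gives > 20000 nM, which is a limit of the assay rather than a measured number. Compound 2 gives > 20000 nM, again a limit. Compound 3 gives > 20000 nM, also a limit. Because all three sit at the limit of > 20000 nM in this assay, at which 3 of the 3 values shown sit, none of the steps between them can be sized: a step that the two limits leave unreadable from compound 1 to compound 2, a step that the two limits leave unreadable from compound 1 to compound 3 and a step that the two limits leave unreadable from compound 2 to compound 3 all stay unreadable.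

Compound 4 `CC(C)CNc1nc(N)nc2c1ncn2/C=C1/CC1(CO)CO` has not yet been measured in this assay. Its difference from compound 2 is isobutyl in place of cyclohexyl on a nitrogen on an aromatic ring. The step from compound 2 to compound 3, which also swaps the cyclohexyl on that nitrogen for a short chain, is the closest guide, yet it gives no size. With every measured neighbour at the limit, the expected step that the limit leaves unreadable from compound 2 to compound 4 is none beyond the scatter, and compound 4 is expected to sit at the limit as well. Compound 4 is therefore estimated at 30000 nM, with a range from 15000 nM to 80000 nM.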

Compound 4, half-maximal cytotoxic concentration: > 20000 nM
Compound 4 gave a limit, no number (the forecaster's own chance of this, stated with the estimate: 80%); the middle value does not contradict the limit.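

In this assay compound 4 also gives only a limit, not a number, so no step from compound 4 to compound 1, compound 2 or compound 3 can be read: the limit of > 20000 nM in this assay, at which 4 of the 4 values shown sit.

The compounds shown leave open how much compound the cells tolerate beyond this limit, and whether any group at this place changes it.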